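A few compounds are considered here, and "the series" means these few. Any claim that something is new, unique, unknown or untested is made for them only; others in the source may bear on it.

Of the compounds shown here, three from this series have been measured in an assay on HEK293 cells for agonist activity at transient receptor potential cation channel subfamily M member 8 (Homo sapiens), read by fluorescence and calcium flux, with a stated time of 15 min; a higher number here means that more compound is needed for the effect, a lower number that less compound is needed. Compound 1 `Cc1ccc(OCC(=O)N(Cc2cccs2)c2ncccn2)cc1` gives 3700 nM. Compound 2 `CCN(Cc1ccco1)C(=O)COc1ccc(C)cc1` gives 489 nM, and compound 3 `Cc1ccc(OCC(=O)N(Cc2cccs2)C2CC2)cc1` gives 8 nM. Among the measured compounds shown here, the single one-place step among them, a 460-fold lower number from compound 1 to compound 3 (2.67 log units; beyond the scatter), is large and concerns the group on the amide-type nitrogen rather than the ring carried on the chain carbon. Among the three numbers compound 2 stands second highest: compound 1 sits above it, beyond the scatter, and compound 3 sits far below it, also beyond the scatter.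

Compound 4 `CCN(Cc1ccccn1)C(=O)COc1ccc(C)cc1` is the untested partner of compound 2. The change is pyridin-2-yl in place of furan-2-yl on a saturated chain carbon bound to an amide-type nitrogen. For the measured compounds named here, no measured step touches this part of the molecule; compounds 1 and 2 differ in more than one place, so their two values alone cannot be read as a ring swap. With nothing in the data that bears directly on this change, the expectation for this assay is a step of modest size from compound 2 to compound 4, in either direction, most likely within the scatter. The estimate for compound 4 is therefore 450 nM, with a range from 150 nM to 1500 nM, meaning an expected step of a 1.1-fold lower number from compound 2 to compound 4 (0.04 log units; within the scatter).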

Compound 4, half-maximal effective concentration: 16000 nM
Beside the measured number, compound 4's estimate is 36-fold (1.55 log units) below it; measured number outside the range, above it.
By their numbers in this assay, from the lowest: compound 3; then compound 2; then compound 1; then compound 4.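

In this assay, the ring on a saturated chain carbon bound to an amide-type nitrogen proves to be a sensitive place: pyridin-2-yl in place of furan-2-yl gives a 33-fold higher number from compound 2 to compound 4 (1.51 log units; beyond the scatter), even though both groups count the same hydrogen-bond donors and acceptors and neither carries a net charge. Among the compounds shown here, the only earlier one-place reading, a 460-fold lower number from compound 1 to compound 3 (2.67 log units; beyond the scatter), concerned the other group on the amide-type nitrogen, so this is the first direct sign that the ring place can also move the number by a large step, here towards a higher number. Nothing available explains why this exchange of one aromatic ring for another has so large an effect.

The compounds shown leave open whether the step follows the change from a five-membered to a six-membered ring or the change of hetero atom from oxygen to nitrogen, and a phenyl or pyridin-3-yl group at this place would bear on that question. As far as these compounds go, it also remains open whether the same exchange would give a step of similar size with cyclopropyl rather than ethyl on the amide-type nitrogen.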